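A Methyl Added to a Secondary Amine

The compounds below may be only part of what the source reports. "The series", "measured", "known", "first", "only" and "open" are said of these compounds alone.

Compound 1 `CCCN(CCC)Cc1ccc(Cl)c(-c2ccccc2OC)c1`: > 10000 nM in an assay on isolated protein for binding affinity to 5-hydroxytryptamine receptor 6 (Homo sapiens) (a higher number here means a weaker inhibitor, a lower number a stronger inhibitor), a limit of the assay rather than a number.
Compound 2 `COc1ccccc1-c1cc(C2CCNC2)ccc1Cl`: 400 nM in this assay.
Compound 3 `CNCc1ccc(Cl)c(-c2ccccc2OC)c1`: 1300 nM in this assay.

Of the two numbers shown, compound 3 gives the highest, with compound 2 nearest at a 3.3-fold higher number from compound 2 to compound 3 (0.51 log units; beyond the scatter). Compound 4 `COc1ccccc1-c1cc(CN(C)C)ccc1Cl` differs from compound 3 by methyl in place of hydrogen on an amine nitrogen. Among the measured compounds shown here, two measured steps bear on this change: an at least 7.6-fold lower number from compound 1 to compound 3 (0.88 log units; beyond the scatter), where a much larger pair of alkyl groups on the amine weakens binding strongly, and a 3.3-fold higher number from compound 2 to compound 3 (0.51 log units; beyond the scatter), where the ring amine of compound 2 outperforms the open chain. A single added methyl is a far smaller change than either, so in this assay a modest rise or no step beyond the scatter is expected, a 1.5-fold higher number from compound 3 to compound 4 (0.19 log units; within the scatter). Compound 4 is therefore estimated at 2000 nM, between 600 nM and 6500 nM.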

Compound 4, inhibition constant: 440 nM
Compound 4: middle estimate off by 4.5-fold (0.66 log units), on the high side, outside the stated range (below it).
By their numbers in this assay, from the lowest: compounds 2 and 4 (each within the scatter of the next); then compound 3. At a limit, above all of these: compound 1.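

In this assay, methyl in place of hydrogen on the amine nitrogen strengthens binding, with a 3.0-fold lower number from compound 3 to compound 4 (0.47 log units; beyond the scatter), so the small change that was expected to do little has a step beyond the scatter. The open chain now matches the ring amine, with a 1.1-fold higher number from compound 2 to compound 4 (0.04 log units; within the scatter), which is within the scatter. Dimethylamino in place of dipropylamino gives an at least 22-fold lower number from compound 1 to compound 4 (1.35 log units; beyond the scatter), a step read from a limit of the assay: the limit of > 10000 nM in this assay, at which 1 of the 4 values shown sits.

From the compounds shown here alone, how binding runs between dimethylamino and dipropylamino, for example with diethylamino, stays open. So does whether a methyl on the ring amine of compound 2 would give a similar step.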